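The compounds below may be only part of what the source reports. "The series", "measured", "known", "first", "only" and "open" are said of these compounds alone.

In a functional assay on HEL cells (Homo sapiens) for cytotoxicity (on this read-out higher numbers stand for lower toxicity in this test and lower numbers for higher toxicity in this test), compound 1 `O=[N+]([O-])c1ccc([C@@H]2OC[C@H]3O[C@@H](c4ccccc4)[C@H](O)[C@@H](O)[C@@H]3O2)cc1` gives > 50 ug/mL, which is a limit of the assay and not a number. Compound 2 `O[C@@H]1[C@@H](O)[C@H](c2ccccc2)O[C@@H]2CO[C@@H](c3ccc(C(F)(F)F)cc3)O[C@@H]12` gives 35 ug/mL. Compound 3 `CO[C@@H]1[C@@H](OC)[C@H](c2ccccc2)O[C@@H]2CO[C@@H](c3ccc(C)cc3)O[C@@H]12` offers no anchor, as its entry reads "not determined" (no result reported). Compound 4 `CO[C@@H]1[C@@H](OC)[C@H](c2ccccc2)O[C@@H]2CO[C@@H](c3ccc4ccccc4c3)O[C@@H]12` differs from compound 3 by naphthalen-2-yl in place of 4-methylphenyl on a saturated ring carbon. Among the compounds with values here, the only measured step bearing on this change, an at least 1.4-fold lower number from compound 1 to compound 2 (0.15 log units; that floor lies within the scatter), is a trifluoromethyl-for-nitro exchange on an aromatic carbon and supports only a loose analogy. Within the data shown here, no step of a particular size or direction can therefore be expected, so the estimate rests on the range spanned by compound 2 at 35 ug/mL. For compound 4 the expected value is 35 ug/mL, with an estimated range of 12 ug/mL to 60 ug/mL.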

Compound 4, half-maximal cytotoxic concentration: > 50 ug/mL
Compound 4: no number, only a limit; the forecaster's own chance of this, stated with the estimate: 45%; middle value at least 1.4-fold (0.15 log units) from the limit.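

In this assay compound 4 gives > 50 ug/mL, which is a limit and not a number. Within the data shown here, compound 3 has no result, so no step from compound 3 to compound 4 can be read. From the compounds shown here alone, what naphthalen-2-yl in place of 4-methylphenyl does to the value stays open.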